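Chloro for Hydroxymethyl in a Dopamine Transporter Series

The compounds below may be only part of what the source reports. "The series", "measured", "known", "first", "only" and "open" are said of these compounds alone.

The account follows a small set of compounds tested in an in vitro assay on HEK293 cells for inhibition of sodium-dependent dopamine transporter (Homo sapiens); on this read-out lower numbers stand for stronger inhibition and higher numbers for weaker inhibition. Compound 1, with the structure `CNC[C@]1(O)Cc2ccccc2[C@@H]1Oc1ccccc1CO`, is measured only as a limit of the assay: in this assay compound 1 gives > 10000 nM. Compound 2, `Cc1ccccc1OC1c2ccccc2CC1(O)CNCCO`, also reaches only a limit, and in this assay compound 2 gives > 10000 nM. Compound 3, `CNC[C@]1(O)Cc2ccccc2[C@@H]1Oc1cc(F)ccc1C`, likewise shows a limit, and in this assay compound 3 gives > 10000 nM. So compound 1 stands at the limit of > 10000 nM in this assay, at which 3 of the 3 values shown sit, with nothing to separate it from the other two.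

The step in question leads from compound 1 to compound 4, `CNC[C@]1(O)Cc2ccccc2[C@@H]1Oc1ccccc1Cl`. The change is chloro in place of hydroxymethyl on an aromatic carbon.

Within the data shown here, no measured step is available here, so the size of the change can only be guessed. Because compound 1 sits at the limit of > 10000 nM in this assay, at which 3 of the 3 values shown sit, together with every other measured compound, the estimated step is an at least 1.2-fold lower number from compound 1 to compound 4 (0.09 log units; that floor lies within the scatter), and it is expected to fall largely within the scatter. Compound 4 is expected to give about 8000 nM, within a range from 2000 nM to 30000 nM.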

Compound 4, half-maximal inhibitory concentration: 10000 nM
For compound 4 the middle estimate is 1.3-fold (0.10 log units) below the measured one; measured number inside the range.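

In this assay, among these compounds, compound 4 gives 10000 nM, the only value in the set that is a number and not a limit of the assay. With chloro on this aromatic carbon the compound therefore gets a readable number, but the comparison with hydroxymethyl stays one-sided, with a number no higher from compound 1 to compound 4 (the limit leaves the size open). The change thus shows no inhibition of a size that can be stated, and the set as a whole remains at the edge of what the assay reads: the limit of > 10000 nM in this assay, at which 3 of the 4 values shown sit.

The compounds shown leave open whether any group at this place, such as bromo, methoxy or an amine, would give a clearly lower number. Among the compounds shown here, they also do not tell whether chloro would matter on a core carrying a different side chain from the one in compound 4.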